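A side chain added to compound 3

This account rests on a few compounds, and the source may have more. Where it says the series, first, only, none or still open, it means among the compounds named here.

Compound 1 `Cc1cn(/C=C/C=O)c(=O)[nH]c1=O` gives 25000 nM
Compound 2 `O=C/C=C/n1ccc(=O)[nH]c1=O` gives 30000 nM
Compound 3 `Cc1cn(C)c(=O)n(/C=C/C=O)c1=O` gives 15000 nM

In a functional assay on HeLa cells (Homo sapiens) for inhibition (on this read-out higher numbers stand for weaker inhibition and lower numbers for stronger inhibition), compound 3 stands within the scatter of both compound 1 and compound 2, so the three values do not separate. Compound 4 `Cc1cn(COCCO)c(=O)n(/C=C/C=O)c1=O` carries 2-hydroxyethoxy in place of hydrogen on a saturated chain carbon bound to an aromatic nitrogen. Within the data shown here, the only measured step, a 1.2-fold higher number from compound 1 to compound 2 (0.08 log units; within the scatter), exchanges a methyl on an aromatic carbon and stays within the scatter. Among the measured compounds shown here, it bears only weakly on this change, and no measured step touches that chain carbon. No shift beyond the scatter is therefore expected, and no firm direction. The expected step is a 1.3-fold higher number from compound 3 to compound 4 (0.12 log units; within the scatter) in this estimate. For compound 4 the estimated value is 20000 nM (expected range 7000 nM to 50000 nM).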

Compound 4, half-maximal inhibitory concentration: 20000 nM
Beside the measured number, compound 4's estimate shows no gap at the digits printed, within the range that was stated.
By their numbers in this assay, from the lowest: compounds 3, 4, 1 and 2 (each within the scatter of the next).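

In this assay the change gives a 1.3-fold higher number from compound 3 to compound 4 (0.12 log units; within the scatter) and so adds the first read on a saturated chain carbon bound to an aromatic nitrogen. Going from methyl to (2-hydroxyethoxy)methyl there, with its added hydrogen-bond donor and acceptors, leaves the number within the scatter, so this one group gives no sign of a shift at this position. Nothing measured here explains this result.

As far as these compounds go, whether an amine, a carboxylic acid or a longer chain on the same carbon would give a step beyond the scatter stays open. From the compounds shown here alone, it is also open whether hydrogen in place of methyl on an aromatic carbon would read the same with 2-hydroxyethoxy present.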